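A few compounds are considered here, and "the series" means these few. Any claim that something is new, unique, unknown or untested is made for them only; others in the source may bear on it.

In an assay on isolated protein with retinoic acid receptor alpha (Homo sapiens) as the target (a higher number here means a larger maximal response, a lower number a smaller maximal response), compound 1, `CC1(C)CCC(C)(C)c2c(F)cc(C(=O)c3ccc4cc(C(=O)O)ccc4c3)cc21`, gives 63%. Compound 2, `CC1(C)CCC(C)(C)c2cc(C(O)c3ccc4cc(C(=O)O)ccc4c3)c(O)cc21`, shares the bicyclic core and the naphthoic acid part but carries a hydroxymethylene bridge and a hydroxy group on the core; in this assay compound 2 gives 0%. Among the measured compounds shown here, of the two numbers known, compound 2 therefore stands at the lowest, and its nearest neighbour is compound 1, which lies higher by a margin that exceeds the usual scatter of this measurement. No single change links compound 1 and compound 2, so the two values can only be set side by side.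

Compound 3, `Cc1cc2c(cc1C(O)c1ccc3cc(C(=O)O)ccc3c1)C(C)(C)CCC2(C)C`, is reached from compound 2 by one change: methyl in place of hydroxy on an aromatic carbon. For the measured compounds named here, since no measured pair shows this exchange, the size of its effect is unknown. Because compound 2 gives 0%, the number can hardly fall further, and a rise toward the level of compound 1 is possible but uncertain. The step from compound 2 to compound 3 is expected to be a number 25 percentage points higher from compound 2 to compound 3 (beyond the scatter). The maximal response of compound 3 is estimated at 25%, within a range from 0% to 60%.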

Compound 3, largest response reached (reported as maximum), in percent of the reference or control that the assay uses: 0%
Estimate against measurement, compound 3: 25 percentage points above; the range from low to high includes it.
By their numbers in this assay, from the lowest: compounds 2 and 3 (each within the scatter of the next); then compound 1.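

In this assay, methyl in place of hydroxy on an aromatic carbon, ortho to a large group, brings no change at the digits printed from compound 2 to compound 3 (within the scatter). Among the compounds shown here, this is the first direct reading at this position, and it shows that, with the hydroxymethylene bridge kept, removing the hydroxy and setting methyl there does not lift the maximal response, as compound 3 gives 0%. Both compounds sit at the same zero reading, so the step cannot show whether the exchange would lower a measurable response, and nothing given here offers an explanation for the outcome.

The compounds shown leave open whether an amine or a methoxy group on this same aromatic carbon would give any measurable response, or whether the result is the same for every group placed there. They also leave open how methyl or hydroxy at this position behaves when the hydroxymethylene bridge is replaced by the carbonyl of compound 1, a pairing that would show whether this position matters once a response is present.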